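The compounds below may be only part of what the source reports. "The series", "measured", "known", "first", "only" and "open" are said of these compounds alone.

Measured so far:
compound 1 `CC[C@@H](Nc1c(C#N)c(-c2ccc(-c3cccc(C)c3F)cc2)nc2cnccc12)C(N)=O` — 3
compound 2 `CCOc1ccccc1-c1ccc(-c2nc3cnccc3c(N)c2C#N)cc1` — 3
compound 3 `CCOc1ccccc1-c1ccc(-c2nc3cnccc3c(N[C@H](CC)C(=O)O)c2C#N)cc1` — 2.1

In a physicochemical assay for lipophilicity, read by HPLC, at pH 7.5 (on this read-out lower numbers stand for lower lipophilicity and higher numbers for higher lipophilicity), compound 1 gives 3, level at the digits shown with compound 2, which gives 3; compound 3, at 2.1, lies lower than both, beyond the scatter. Among the measured compounds shown here, the one step within the set is a number 0.90 log units lower from compound 2 to compound 3 (beyond the scatter), a modest drop tied to a 1-carboxypropyl in place of hydrogen on a nitrogen on an aromatic ring.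

Compound 4 `CC[C@@H](Nc1c(C#N)c(-c2ccc(-c3ccccc3OC)cc2)nc2cnccc12)C(N)=O` is not yet measured in this assay. It differs from compound 1 in one place: 2-methoxyphenyl in place of 2-fluoro-3-methylphenyl on an aromatic carbon. No measured pair in the set changes this position, so the step from compound 2 to compound 3 does not bear on it, and the two values of compound 1 and compound 2, though they carry different groups at this position and elsewhere, show no difference at the digits shown.

For compound 4 the expected step is therefore a number 0.20 log units lower from compound 1 to compound 4 (within the scatter), most likely within the scatter, with the estimate placed at 2.8 and a range from 2.3 to 3.3.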

Compound 4, distribution coefficient: 2.7
Compound 4: the middle estimate sits 0.10 log units above what was measured, within the range that was stated.
By their numbers in this assay, from the lowest: compound 3; then compounds 4, 1 and 2 (each within the scatter of the next).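

Among the compounds shown here, at the aromatic carbon para to a large group, the first pair that changes this position gives, in this assay, a number 0.30 log units lower from compound 1 to compound 4 (within the scatter). The 2-methoxyphenyl and 2-fluoro-3-methylphenyl groups both have 8 heavy atoms, and 2-methoxyphenyl carries 1 hydrogen-bond acceptor where 2-fluoro-3-methylphenyl has 0, so in this one pair that difference in count comes with a step that stays within the scatter. No supporting measurement bears on the origin of this step.

Going by these compounds, whether this position tolerates exchange as closely with a group of another kind, such as a piperazine or a longer propoxy chain, stays open. Also open, on these data alone, is how a plain phenyl at this position, on the core of compound 1, would read against these two substituted rings.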